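The compounds below may be only part of what the source reports. "The series", "measured", "known", "first", "only" and "open" are said of these compounds alone.

Compound 3, built as `C=CCn1c(=O)/c(=C\c2ccccc2OC)[nH]c(=O)/c1=C\c1ccccc1OC`, gives 21200 nM in a functional assay on Huh-7 cells (Homo sapiens) for cytotoxicity, read by CCK-8 assay, with a stated time of 72 h (on this read-out higher numbers stand for weaker inhibition and lower numbers for stronger inhibition), the highest of the two numbers seen so far. Its nearest neighbour on that scale, compound 1 with the structure `C=CCn1c(=O)/c(=C\c2cccc(Cl)c2)[nH]c(=O)/c1=C\c1ccccc1OC`, gives 8900 nM in this assay. Compound 2, drawn as `C=CCn1c(=O)/c(=C\c2cc(Br)ccc2F)[nH]c(=O)/c1=C\c1ccccc1OC`, is recorded in this assay as "not active" (no number reported), so no number is available for it.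

The new compound 4 has the structure `C=CCn1c(=O)/c(=C\c2cccc(C)c2)[nH]c(=O)/c1=C\c1ccccc1OC`. It differs from compound 3 in one place: 3-methylphenyl in place of 2-methoxyphenyl on a double-bonded chain carbon bound to an aromatic carbon. For the measured compounds named here, the one measured step that touches this position, a 2.4-fold higher number from compound 1 to compound 3 (0.38 log units; beyond the scatter), runs the opposite way, from a phenyl carrying a substituent in the three-position to the 2-methoxyphenyl, and raised the number by a modest amount beyond the scatter. Compound 4 returns to a phenyl with a substituent in the three-position, though a methyl rather than a chlorine, so the earlier step can only loosely guide the expectation. Compound 2, which bears a differently substituted phenyl at this place, gives no number and offers no direction.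

On this basis the step from compound 3 to compound 4 is expected to be a 1.8-fold lower number from compound 3 to compound 4 (0.25 log units; within the scatter), a modest fall in the number. Compound 4 is therefore estimated at 12000 nM in this assay, with a plausible range from 5000 nM to 30000 nM.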

Compound 4, half-maximal inhibitory concentration: 21400 nM
Compound 4: middle estimate off by 1.8-fold (0.25 log units), on the low side; the measured number falls inside the stated range.
By their numbers in this assay, from the lowest: compound 1; then compounds 3 and 4 (each within the scatter of the next).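

In this assay, the exchange of the 2-methoxyphenyl for the 3-methylphenyl gives a 1.0-fold higher number from compound 3 to compound 4 (0.00 log units; within the scatter) and so leaves two numbers that cannot be told apart, even though the group loses its oxygen and its substituent sits elsewhere on the phenyl. The other new step, with methyl in place of chloro on an aromatic carbon, gives a 2.4-fold higher number from compound 1 to compound 4 (0.38 log units; beyond the scatter) and shows that a substituent in the three-position does not by itself match compound 1; among the compounds with numbers, the one carrying the 3-chlorophenyl stands apart, while those carrying the 2-methoxyphenyl and the 3-methylphenyl stay together. No measurement shown here explains either step.

Going by these compounds, because the swap from compound 3 to compound 4 alters both the substituent and its place on the phenyl, the effect of each taken alone remains open, and a 3-methoxyphenyl or a 2-methylphenyl would separate them. On these data alone, it is also open whether a phenyl bearing an amine or a carboxylic acid at this place would give a lower or higher number than the chloro compound.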